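Shortening a Chain Into a Carbamate on a Piperazine Core

A few compounds are considered here, and "the series" means these few. Any claim that something is new, unique, unknown or untested is made for them only; others in the source may bear on it.

Compound 1 `CCCCCCCC(=O)OCC1CN(C(=O)c2cc(OC)c(OC)c(OC)c2)CCN1C(=O)c1cc(OC)c(OC)c(OC)c1` carries a heptylcarbonyl ester on the shared core. In a functional assay (Oryctolagus cuniculus) for inhibition of platelet-activating factor receptor (Cavia porcellus) (on this read-out lower numbers stand for stronger inhibition and higher numbers for weaker inhibition), compound 1 gives 310 nM, the lowest of the two numbers recorded so far. Within the data shown here, its only measured neighbour is compound 2 `CCCCCCCCCCCCCCCCCC(=O)OCC1CN(C(=O)c2cc(OC)c(OC)c(OC)c2)CCN1C(=O)c1cc(OC)c(OC)c(OC)c1`, which differs by decyl in place of hydrogen on a saturated chain carbon, seven bonds along the chain from a carbonyl carbon; in this assay compound 2 gives 45000 nM. The step of a 150-fold higher number from compound 1 to compound 2 (2.16 log units; beyond the scatter) shows that growing the chain at this end made inhibition much weaker.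

Compound 3 `COc1cc(C(=O)N2CCN(C(=O)c3cc(OC)c(OC)c(OC)c3)C(COC(=O)NC(C)(C)C)C2)cc(OC)c1OC` goes the other way in size: (tert-butyl)amino in place of heptyl on a carbonyl carbon, so a heptylcarbonyl ester becomes a (tert-butyl)carbamoyl ester. Among the measured compounds shown here, the one measured step bears on it only loosely, since it tested lengthening rather than shortening and swapping in a hydrogen-bond donor. With so little to go on, compound 3 is expected to stay roughly where compound 1 stands, with a step of a 1.9-fold higher number from compound 1 to compound 3 (0.29 log units; within the scatter) allowed in either direction. The estimate for compound 3 in this assay is 600 nM, within a range from 120 nM to 3000 nM.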

Compound 3, half-maximal inhibitory concentration: 130 nM
Compound 3: the middle estimate sits 4.6-fold (0.66 log units) above what was measured; measured number inside the range.
By their numbers in this assay, from the lowest: compound 3; then compound 1; then compound 2.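

Swapping heptyl for (tert-butyl)amino on the carbonyl carbon gives a 2.4-fold lower number from compound 1 to compound 3 (0.38 log units; beyond the scatter) in this assay. This modest gain shows that the position does not need a long straight carbon chain: a smaller, branched group that brings in a nitrogen and a hydrogen-bond donor keeps inhibition and slightly strengthens it, whereas the earlier step, a 150-fold higher number from compound 1 to compound 2 (2.16 log units; beyond the scatter), showed only that lengthening the chain costs a great deal. No separate measurement bears on what lies behind this gain.

This single change alters chain length, branching and the atom attached to the carbonyl carbon all at once, so the contribution of each stays unresolved. A tert-butyl or neopentyl group on the same carbonyl carbon would test whether the nitrogen matters, while a straight-chain butylamino group would test whether the branching does, and a plain butyl chain would show how much of the gain comes from shortening alone.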